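Arylsulfamate series: amide-linked anilines on the shared core

The compounds below may be only part of what the source reports. "The series", "measured", "known", "first", "only" and "open" are said of these compounds alone.

Three compounds have been measured in an assay on HEK293 cells for inhibition of Steryl-sulfatase (Homo sapiens), tested at 1 uM; on this read-out higher numbers stand for a stronger effect at the one concentration tested and lower numbers for a weaker effect:

Compound 1, `NS(=O)(=O)Oc1ccc2c(c1)CN(C(=O)c1cccc(N3CCC(N4CCCCC4)CC3)c1)CC2`, gives 8%.
Compound 2, `CCN(Cc1ccncc1)c1cccc(C(=O)N2CCc3ccc(OS(N)(=O)=O)cc3C2)c1`, gives 52.8%.
Compound 3, `NS(=O)(=O)Oc1ccc2c(c1)CN(C(=O)c1cccc(N3CCN(Cc4ccccc4)CC3)c1)CC2`, gives 23.7%.

Compound 2 carries the highest number of the three in this assay. The nearest is compound 3, whose number is lower by an amount beyond the scatter; the furthest is compound 1, lower still, also beyond the scatter. Both compound 1 and compound 3 carry a ring-bearing amino group on the aromatic carbon meta to the amide, and both fall well under compound 2.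

Compound 4, `CN(C)CCN(CCN(C)C)c1cccc(C(=O)N2CCc3ccc(OS(N)(=O)=O)cc3C2)c1`, has not yet been measured. It differs from compound 2 in one place: bis(2-(dimethylamino)ethyl)amino in place of ethyl((pyridin-4-yl)methyl)amino on an aromatic carbon.

Among the compounds with values here, no single-point step between measured compounds is available, so the expected size of the change rests only on the spread of the three numbers. Given that compound 1 and compound 3 sit far below compound 2 in this assay, a downward step from compound 2 to compound 4 is expected, of about a number 27.8 percentage points lower from compound 2 to compound 4 (beyond the scatter), beyond the scatter. Compound 4 is therefore estimated at 25%, with a range from 5% to 48%.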

Compound 4, a percentage reported as inhibition, at one concentration (the size of the read-out at that concentration, not a potency): 17.1%
For compound 4 the middle estimate is 7.9 percentage points above the measured one, within the range that was stated.
By their numbers in this assay, from the lowest: compounds 1, 4 and 3 (each within the scatter of the next, the first and the last beyond it); then compound 2.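

In this assay, within the data shown here, this aromatic carbon, meta to a large group, is sensitive to the choice of amino substituent: bis(2-(dimethylamino)ethyl)amino in place of ethyl((pyridin-4-yl)methyl)amino gives a number 35.7 percentage points lower from compound 2 to compound 4 (beyond the scatter), the first step that changes one place only, and a large one. The heavy-atom count hardly moves, so the step is not a matter of substituent size by that count; what changes is that a six-membered aromatic ring with 1 hetero atom leaves and an entering group with no ring takes its place. Nothing available explains the step.

The change removes the pyridine ring and the ethyl group and adds both dimethylaminoethyl arms at once, so the part responsible stays unresolved. A benzyl(ethyl)amino group or a plain diethylamino group at this carbon would separate these contributions.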